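Trading a phenyl for an ethyl in an EP4 agonist series

The source may report more compounds than this note shows. Statements on the series, on what has been measured and on what is new or still open speak of the compounds shown alone.

Of the compounds shown here, three sharing one core have been measured in a functional assay on CHO cells for agonist activity at prostaglandin E2 receptor EP4 subtype (Rattus norvegicus), read by cAMP accumulation and immunoassay, with a stated time of 10 min; a higher number here means that more compound is needed for the effect, a lower number that less compound is needed. Compound 1 `O=C(O)CCCSCCN1C(=O)OC[C@@H]1/C=C/[C@@H](O)Cc1ccccc1`, which carries only hydrogen at the position in question, gives 36 nM. Compound 2 `O=C(O)CCCSCCN1C(=O)OC[C@@H]1/C=C/[C@@H](O)Cc1cccc(C(F)(F)F)c1`, with a trifluoromethyl group there, gives 12 nM. Compound 3 `O=C(O)CCCSCCN1C(=O)OC[C@@H]1/C=C/[C@@H](O)Cc1cccc(-c2ccccc2)c1`, with a phenyl group at that place, gives 450 nM, the highest number of the three, far above compound 1 and compound 2. The steps that lead to it are large: a 13-fold higher number from compound 1 to compound 3 (1.10 log units; beyond the scatter), and a 38-fold higher number from compound 2 to compound 3 (1.57 log units; beyond the scatter); by contrast, a 3.0-fold lower number from compound 1 to compound 2 (0.48 log units; beyond the scatter).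

Compound 4 `CCc1cccc(C[C@H](O)/C=C/[C@H]2COC(=O)N2CCSCCCC(=O)O)c1` is not yet measured. It differs from compound 3 in one place: ethyl in place of phenyl on an aromatic carbon. The ethyl group is far smaller than the phenyl it replaces and closer in size to the hydrogen of compound 1 and the trifluoromethyl of compound 2, both of which gave much lower numbers than compound 3. The two steps that introduced the phenyl were both large rises, so removing most of that group is expected to undo much of the rise. In this assay compound 4 is therefore estimated at 25 nM, within a range of 8 nM to 90 nM, which means an expected step of an 18-fold lower number from compound 3 to compound 4 (1.26 log units; beyond the scatter).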

Compound 4, half-maximal effective concentration: 18 nM
Compound 4: middle estimate off by 1.4-fold (0.14 log units), on the high side, within the range that was stated.
By their numbers in this assay, from the lowest: compounds 2, 4 and 1 (each within the scatter of the next, the first and the last beyond it); then compound 3.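

Replacing phenyl with ethyl in this assay brings a large drop in the number (a 25-fold lower number from compound 3 to compound 4 (1.40 log units; beyond the scatter)), which shows that the high value of compound 3 does not extend to every carbon group at this position on the aromatic ring. Ethyl also sits within the scatter of both smaller-numbered neighbours, trifluoromethyl (a 1.5-fold higher number from compound 2 to compound 4 (0.18 log units; within the scatter)) and hydrogen (a 2.0-fold lower number from compound 1 to compound 4 (0.30 log units; within the scatter)), so among these four compounds only the phenyl of compound 3 stands clearly apart, even though compound 1 and compound 2 differ from each other beyond the scatter. No measurement shown here gives a reason why the phenyl group stands apart.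

From the compounds shown here alone, it remains open whether a longer chain such as butyl or a saturated ring such as cyclohexyl would read like ethyl or like phenyl, which would help separate the number of carbons from the presence of an aromatic ring. Going by these compounds, how an amine or a carboxylic acid at this same place would read also remains unknown.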